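Urea-to-benzamide step in a pyrazole growth-inhibitor series

A few compounds are considered here, and "the series" means these few. Any claim that something is new, unique, unknown or untested is made for them only; others in the source may bear on it.

Measured so far:
compound 1 `COc1cc(-c2nn(-c3cccc(NC(=O)Nc4ccc(Cl)c(Cl)c4)c3)cc2-c2ccncc2)ccc1Cl` — 1210 nM
compound 2 `O=C(Nc1cccc(-n2cc(-c3ccncc3)c(-c3ccc(Cl)c(O)c3)n2)c1)Nc1ccc(Cl)c(Cl)c1` — 1190 nM
compound 3 `O=C(Nc1cccc(-n2cc(-c3ccncc3)c(-c3ccc(Cl)c(O)c3)n2)c1)Nc1cc(C(F)(F)F)cc(C(F)(F)F)c1` — 428 nM

In a functional assay on HCT-116 cells (Homo sapiens) for inhibition, read by sulforhodamine B assay, with a stated time of 48 h (a lower number here means a stronger inhibitor of growth, a higher number a weaker inhibitor of growth), compound 1 gives 1210 nM, the highest of the three numbers. Its nearest neighbour is compound 2, and the step of a 1.0-fold lower number from compound 1 to compound 2 (0.01 log units; within the scatter) is within the scatter, so the two cannot be placed in order. For the measured compounds named here, compound 3 sits furthest away; compound 2 gives 1190 nM and compound 3 gives 428 nM, and these two differ in the aryl group on the far end, with no single-point step recorded between them.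

Compound 4 `COc1cc(-c2nn(-c3cccc(NC(=O)c4ccccc4)c3)cc2-c2ccncc2)ccc1Cl` is the next compound to be measured. It differs from compound 1 by phenyl in place of (3,4-dichlorophenyl)amino on a carbonyl carbon: the ((3,4-dichlorophenyl)carbamoyl)amino group becomes benzamido, so one hydrogen-bond donor and both chlorine atoms go. Going by the values given here, no measured step covers this kind of change; the only step recorded, from compound 1 to compound 2, touches the methoxy group and is within the scatter, so it gives no guidance here. Removing the dichlorophenyl amino portion strips out the part of the molecule that the compound 2 to compound 3 comparison shows to matter, so a weakening is expected. The step of a 3.3-fold higher number from compound 1 to compound 4 (0.52 log units; beyond the scatter) is expected to give a higher number. Compound 4 is estimated at 4000 nM, within 1200 nM to 15000 nM.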

Compound 4, concentration for 50% growth inhibition: 500 nM
The estimate for compound 4 lay 8.0-fold (0.90 log units) above the measured number, outside the stated range (below it).
By their numbers in this assay, from the lowest: compounds 3 and 4 (each within the scatter of the next); then compounds 2 and 1 (each within the scatter of the next).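

In this assay, replacing (3,4-dichlorophenyl)amino with phenyl on a carbonyl carbon gives a 2.4-fold lower number from compound 1 to compound 4 (0.38 log units; beyond the scatter), so the urea linkage and the dichlorophenyl ring are not required for growth inhibition in this pair, and the shorter benzamido group is the better of the two here. For the compounds shown here, this is the first reading at this position, as the earlier step between compounds with and without the methyl on the oxygen touched only the other end of the molecule and stayed within the scatter. The change removes the amino nitrogen with its hydrogen-bond donor and both chlorine atoms at once, and no measurement bearing on the reason for the step is available.

The pair cannot separate the contribution of the amino nitrogen from that of the chlorine atoms, and a 3,4-dichlorobenzoyl group in place of benzoyl would be the direct test of that split. Also open, as far as these compounds go, are whether the step carries over to the hydroxy compounds and the bis(trifluoromethyl)phenyl urea, and how an aminomethyl group or a carboxylic acid on the benzamide phenyl would read.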